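The source may hold more compounds than are shown below. What is called first, only, known or untested is meant among the compounds shown, and "the series" means these compounds.

The measured compounds, each with its result in an ADME assay on NIH3T3 cells (Mus musculus) for cytotoxicity, read by XTT assay, with a stated time of 24 h; on this read-out higher numbers stand for weaker inhibition and lower numbers for stronger inhibition:

Compound 1 `Fc1ccc(C2CC(c3ccc(Cl)s3)=NN2c2nc(-c3ccc(C(F)(F)F)cc3)cs2)cc1` — in this assay compound 1 sits at the limit > 500 ug/mL, a limit of the assay rather than a number.
Compound 2 `Cc1ccc(C2=NN(c3nc(-c4ccc([N+](=O)[O-])cc4)cs3)C(c3ccc(F)cc3)C2)s1` — in this assay compound 2 gives 15.6 ug/mL.
Compound 3 `Fc1ccc(-c2csc(N3N=C(c4ccc(Cl)s4)CC3c3ccc(F)cc3)n2)cc1` — in this assay compound 3 sits at the limit > 500 ug/mL, again a limit rather than a number.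

Going by the values given here, compound 3 therefore stands at the limit, as does compound 1, which is the one measured step touching it: a step that the two limits leave unreadable from compound 1 to compound 3. Because both ends of that step sit at the limit of > 500 ug/mL in this assay, at which 2 of the 3 values shown sit, its size cannot be read, and it says nothing about how far a change on that phenyl ring can move the number.

Compound 4 `O=[N+]([O-])c1ccc(-c2csc(N3N=C(c4ccc(Cl)s4)CC3c3ccc(F)cc3)n2)cc1` differs from compound 3 in one place: nitro in place of fluoro on an aromatic carbon. Among the compounds with values here, no measured step covers this change. Compound 2 also carries a nitro on that phenyl ring and gives a number well inside the assay range, whereas compound 3 does not, but the two differ elsewhere too, so only the values themselves can be compared. Compound 4 is expected to come in with stronger inhibition than the limit of compound 3, an expected step of an at least 16-fold lower number from compound 3 to compound 4 (1.22 log units; beyond the scatter). The estimate for compound 4 is 30 ug/mL, between 6 ug/mL and 250 ug/mL, with a real chance that it too is reported only as a limit.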

Compound 4, half-maximal inhibitory concentration: > 500 ug/mL
Compound 4: no number, only a limit; the forecaster's own chance of this, stated with the estimate: 30%; at least 16-fold (1.22 log units) between middle value and limit.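

Going by these compounds alone, with nitro on the phenyl ring in both compounds, methyl and chloro on the other aromatic ring part them: the one readable step is an at least 32-fold higher number from compound 2 to compound 4 (1.50 log units; beyond the scatter). So in this assay, 4-nitrophenyl does not bring a number inside the assay range on its own, and compound 2 stays the only compound here with a real number, while compound 1, compound 3 and compound 4 all carry chloro. The steps among these three cannot be read, because all three sit at the same limit: the limit of > 500 ug/mL in this assay, at which 3 of the 4 values shown sit.

Still open, on these data alone, is whether methyl in place of chloro would also give a number with 4-fluorophenyl, which would show how far that one place acts apart from the nitro. As far as these compounds go, how an amine or a longer chain in that place would read also remains unknown.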